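Bromo for methyl on the oxindole-type ring of compound 2

A few compounds are considered here, and "the series" means these few. Any claim that something is new, unique, unknown or untested is made for them only; others in the source may bear on it.

Compound 1 `CCn1c(/C=C2/C(=O)Nc3ccccc32)nc2ccccc21` is the parent; in a functional assay on PC-3 cells (Homo sapiens) for cytotoxicity, read by MTT assay, with a stated time of 48 h (a higher number here means a weaker inhibitor, a lower number a stronger inhibitor), compound 1 gives 38000 nM. Among the measured compounds shown here, compound 2 `CCn1c(/C=C2/C(=O)Nc3ccc(C)cc32)nc2ccccc21` carries a methyl, and in this assay compound 2 gives 38600 nM, the higher of the two numbers known, with compound 1 as its only neighbour. For the measured compounds named here, the only step known, a 1.0-fold higher number from compound 1 to compound 2 (0.01 log units; within the scatter), bears on the change to compound 3 `CCn1c(/C=C2/C(=O)Nc3ccc(Br)cc32)nc2ccccc21`, which is bromo in place of methyl on an aromatic carbon. Going by the values given here, with one unchanged step as the sole guide, no step beyond the scatter is expected in this assay from compound 2 to compound 3, a 1.1-fold lower number from compound 2 to compound 3 (0.04 log units; within the scatter). For compound 3 the estimate is 35000 nM, between 15000 nM and 80000 nM.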

Compound 3, half-maximal inhibitory concentration: 42700 nM
Estimate against measurement, compound 3: 1.2-fold (0.09 log units) below; the range from low to high includes it.
By their numbers in this assay, from the lowest: compounds 1, 2 and 3 (each within the scatter of the next).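

In this assay bromo in place of methyl gives a 1.1-fold higher number from compound 2 to compound 3 (0.04 log units; within the scatter) and bromo in place of hydrogen gives a 1.1-fold higher number from compound 1 to compound 3 (0.05 log units; within the scatter) on the same aromatic carbon. The flat reading at this position now extends to a second substituent: hydrogen, methyl and bromo all stand within the scatter of one another. Nothing at hand accounts for this result.

As far as these compounds go, whether an amine or a carboxylic acid on this carbon would give a step beyond the scatter remains open. So does the effect of a longer chain elsewhere on the shared core.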